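Adding a 4-methoxyphenyl to compound 2's ring nitrogen

This account rests on a few compounds, and the source may have more. Where it says the series, first, only, none or still open, it means among the compounds named here.

- compound 1 (`O=C1COc2ccc(-c3cnc(Cl)c(NS(=O)(=O)c4ccc(F)cc4)c3)cc2N1C1CCCCC1`): > 40000 nM (a limit, not a number)
- compound 2 (`O=C1COc2ccc(-c3cccc(NS(=O)(=O)c4ccc(F)cc4)c3)cc2N1`): 20100 nM
- compound 3 (`COc1cccc(N2C(=O)COc3ccc(-c4ccc(O)cc4)cc32)c1`): 30400 nM

These compounds were tested in a functional assay on A-375 cells (Homo sapiens) for antiproliferative activity, read by MTT assay, with a stated time of 72 h; on this read-out higher numbers stand for weaker inhibition and lower numbers for stronger inhibition. Compound 2 gives 20100 nM and compound 3 gives 30400 nM, and these two values lie within the usual scatter of each other. Compound 1 reaches only a limit of the assay, > 40000 nM, so it has no exact number.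

The next compound to be measured is compound 4 (`COc1ccc(N2C(=O)COc3ccc(-c4cccc(NS(=O)(=O)c5ccc(F)cc5)c4)cc32)cc1`). Compared with compound 2, it has 4-methoxyphenyl in place of hydrogen on an amide-type nitrogen in a ring. No measured pair among these compounds isolates this change, so any forecast is loose.

Compound 3 also carries an aromatic ring with a methoxy group on that nitrogen, and its value of 30400 nM gives no sign of stronger inhibition than in compound 2, but it differs from compound 4 elsewhere too. The expectation in this assay is therefore no shift beyond the scatter, though a larger move in either direction remains possible. The expected change is a 1.4-fold lower number from compound 2 to compound 4 (0.16 log units; within the scatter). For compound 4 the estimate is 14000 nM, with an expected range from 2500 nM to 40000 nM.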

Compound 4, half-maximal inhibitory concentration: 38500 nM
For compound 4 the middle estimate is 2.8-fold (0.44 log units) below the measured one; the measured number falls inside the stated range.
By their numbers in this assay, from the lowest: compounds 2, 3 and 4 (each within the scatter of the next). At a limit, above all of these: compound 1.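

In this assay, placing 4-methoxyphenyl on the amide-type nitrogen in the ring gives a 1.9-fold higher number from compound 2 to compound 4 (0.28 log units; within the scatter), so this single change produces no shift that can be told apart from repeat-to-repeat variation. For the compounds shown here, this is the first direct reading of this position, since the earlier compounds differ from one another in more than one place. It shows that a hydrogen on this nitrogen can give way to a whole aromatic ring without any clear gain or loss in inhibition, but the reading has limited reach because the compounds lie close to the top of the range read here: the limit of > 40000 nM in this assay, at which 1 of the 4 values shown sits.

As far as these compounds go, whether a much smaller group on this nitrogen, such as methyl, or a chain ending in an amine or a carboxylic acid would move the number beyond the scatter stays open. Going by these compounds alone, also open is whether this nitrogen would matter more on a compound giving much stronger inhibition, as compound 1 and compound 3 differ from compound 2 in several places and offer no further step to read.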